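The source may hold more compounds than are shown below. What is called first, only, known or untested is meant among the compounds shown, and "the series" means these compounds.

Measured compounds:
compound 1, `Cc1ccc(NCc2cn(-c3ccccc3)nc2-c2ccc(C)cc2)cc1`: 7260 nM
compound 2, `Cc1ccc(-c2nn(-c3ccccc3)cc2CNc2ccc(F)cc2)cc1`: 5880 nM
compound 3, `Cc1ccc(NCc2cn(-c3ccccc3)nc2-c2ccc(Br)cc2)cc1`: 5380 nM

These three compounds were tested in a functional assay on MCF7 cells (Homo sapiens) for antiproliferative activity, read by MTT assay, with a stated time of 48 h; a higher number here means a weaker inhibitor, a lower number a stronger inhibitor. In this assay compound 1 gives 7260 nM, compound 2 gives 5880 nM and compound 3 gives 5380 nM. Compound 2 differs from compound 1 by one change, (fluoro in place of methyl on an aromatic carbon), and that change made a step of a 1.2-fold lower number from compound 1 to compound 2 (0.09 log units; within the scatter). Compound 3 differs from compound 1 at a different position, (bromo in place of methyl on an aromatic carbon), with a step of a 1.3-fold lower number from compound 1 to compound 3 (0.13 log units; within the scatter). All three values sit within the scatter of one another.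

Compound 4, `Fc1ccc(NCc2cn(-c3ccccc3)nc2-c2ccc(Br)cc2)cc1`, has not yet been tested. It differs from compound 3 by fluoro in place of methyl on an aromatic carbon, which is the same change, at the same place, that turns compound 1 into compound 2. Since that change made a step of a 1.2-fold lower number from compound 1 to compound 2 (0.09 log units; within the scatter), a step of about the same size is expected from compound 3 to compound 4, namely a 1.1-fold lower number from compound 3 to compound 4 (0.06 log units; within the scatter). On that basis compound 4 is estimated at 4700 nM, with a likely range from 2400 nM to 9200 nM.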

Compound 4, half-maximal inhibitory concentration: 3960 nM
Beside the measured number, compound 4's estimate is 1.2-fold (0.07 log units) above it; measured number inside the range.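

In this assay, among the compounds shown here, fluoro in place of methyl gave a 1.4-fold lower number from compound 3 to compound 4 (0.13 log units; within the scatter), and this step agrees with the one seen for the same change on the other core: the same change on two cores in this assay, a 1.2-fold lower number (0.09 log units; within the scatter) from compound 1 to compound 2 and a 1.4-fold lower number (0.13 log units; within the scatter) from compound 3 to compound 4, 1.1-fold (0.04 log units) apart, within the scatter of two such steps Bromo in place of methyl gave a 1.5-fold lower number from compound 2 to compound 4 (0.17 log units; within the scatter), and this step likewise agrees with its earlier counterpart: the same change on two cores in this assay, a 1.3-fold lower number (0.13 log units; within the scatter) from compound 1 to compound 3 and a 1.5-fold lower number (0.17 log units; within the scatter) from compound 2 to compound 4, 1.1-fold (0.04 log units) apart, within the scatter of two such steps Both changes therefore carry from one core to the other with steps of matching size, but every step lies within the scatter, so the agreement shows only that neither change moved the number measurably on either core, not that either has a real effect that transfers.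

The compounds shown leave open whether an amine, a carboxylic acid or a longer chain in place of methyl would give a step beyond the scatter, and whether such a step would then carry between cores. They also leave open whether this agreement would hold on a core altered elsewhere in the molecule.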